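The source may report more compounds than this note shows. Statements on the series, on what has been measured and on what is new or still open speak of the compounds shown alone.

- compound 1 `O=C1/C(=N\NC(=S)NO)c2cc(F)ccc2N1CN1CCN(c2ccc(Cl)cc2)CC1` gives 194000 nM
- compound 2 `COc1ccc(N2CCN(CN3C(=O)/C(=N\NC(=S)NO)c4cc(F)ccc43)CC2)cc1` gives 260000 nM
- compound 3 `CONC(=S)N/N=C1\C(=O)N(CN2CCN(c3ccccc3)CC2)c2ccc(F)cc21` gives 227000 nM

In an ADME assay on MT4 cells (Homo sapiens) for cytotoxicity, read by spectrophotometry, with a stated time of 5 days (a lower number here means that less compound is tolerated, a higher number that more compound is tolerated), compound 3 gives 227000 nM and so stands within the usual scatter of both compound 1 and compound 2, with no real order among the three. Compound 4 `O=C1/C(=N\NC(=S)NO)c2cc(F)ccc2N1CN1CCN(c2ccccc2)CC1` has not yet been measured. It differs from compound 3 by hydrogen in place of methyl on an oxygen and the change is hydrogen in place of methyl on an oxygen, which turns methoxyamino into hydroxyamino.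

Going by the values given here, the only measured step (a 1.3-fold higher number from compound 1 to compound 2 (0.13 log units; within the scatter)) lies on an aromatic carbon rather than on that oxygen, so it bears on this change only indirectly. It does show that the values stayed close when that other place changed. Among the compounds with values here, compound 1 with 194000 nM and compound 2 with 260000 nM already carry the hydroxyamino group and sit within the scatter of compound 3, although no measured pair isolates this swap.

Therefore a 1.0-fold lower number from compound 3 to compound 4 (0.00 log units; within the scatter) is the estimated step in this assay and it is not expected to exceed the scatter. For compound 4 the estimated value is 225000 nM with an expected range from 130000 nM to 390000 nM in this estimate.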

Compound 4, half-maximal cytotoxic concentration: 251000 nM
For compound 4 the middle estimate is 1.1-fold (0.05 log units) below the measured one; measured number inside the range.
By their numbers in this assay, from the lowest: compounds 1, 3, 4 and 2 (each within the scatter of the next).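

In this assay, the pair of compound 3 and compound 4 isolates the swap of methyl for hydrogen on an oxygen whose other neighbour is an amide-type nitrogen, and it gives a 1.1-fold higher number from compound 3 to compound 4 (0.04 log units; within the scatter). Turning methoxyamino into hydroxyamino therefore leaves the number within the scatter in this one matched pair, which the earlier compounds could suggest only indirectly. Compound 4 also supplies the hydrogen reference for the aromatic carbon that carries methoxy or chloro in the earlier hydroxyamino compounds, with a 1.0-fold lower number from compound 2 to compound 4 (0.02 log units; within the scatter) and with a 1.3-fold higher number from compound 1 to compound 4 (0.11 log units; within the scatter), so hydrogen, methoxy and chloro there all lie within the scatter of one another, and nothing in the material shown accounts for how closely these numbers agree.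

Going by these compounds alone, the oxygen swap is seen only with hydrogen on that aromatic carbon, so it remains open whether it would behave the same way with chloro or methoxy there. Also open, on these data alone, is whether a longer chain such as ethyl on that oxygen, or an amine or a carboxylic acid on the aromatic carbon, would stay within the scatter in this assay.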